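Acyloxymethyl carbamate in place of trichloroethyl carbamate

The source may report more compounds than this note shows. Statements on the series, on what has been measured and on what is new or still open speak of the compounds shown alone.

Compound 3 `C[C@@H]1CN(C(=O)c2nc(Nc3cc(C4CC4)[nH]n3)c3cc(Cl)ccc3n2)CCN1C(=O)OCC(Cl)(Cl)Cl` stands second highest of the three numbers in an assay for inhibition of serine/threonine-protein kinase PAK 4 (Homo sapiens), read by FRET and Z'-LYTE, with a stated time of 60 min, tested at 0.5 uM, in the presence of a further agent that is not named here; on this read-out higher numbers stand for a stronger effect at the one concentration tested and lower numbers for a weaker effect: compound 3 gives -1.5%. Its nearest neighbour is compound 2 `CC(OC(=O)N1CCN(C(=O)c2nc(Nc3cc(C4CC4)[nH]n3)c3cc(Cl)ccc3n2)C[C@H]1C)OC(=O)C(C)(C)C`, which gives -6.9%, a gap that lies within the scatter; furthest away is compound 1 `CC(C)C(=O)OCOC(=O)N1CCN(C(=O)c2nc(Nc3cc(C4CC4)[nH]n3)c3cc(Cl)ccc3n2)C[C@H]1C`, which gives 16.4%, a gap beyond the scatter.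

Compound 4 `C[C@@H]1CN(C(=O)c2nc(Nc3cc(C4CC4)[nH]n3)c3cc(Cl)ccc3n2)CCN1C(=O)OCOC(=O)C(C)(C)C` differs from compound 3 by ((tert-butyl)carbonyl)oxy in place of trichloromethyl on a saturated chain carbon bound to an oxygen next to a carbonyl group. Among the compounds with values here, two measured steps bear on this change. The step of a number 17.9 percentage points lower from compound 1 to compound 3 (beyond the scatter) replaced an acyloxy group on that carbon by trichloromethyl; compound 4 reverses that kind of change, with ((tert-butyl)carbonyl)oxy in place of trichloromethyl. The step of a number 23.3 percentage points lower from compound 1 to compound 2 (beyond the scatter) shows that the tert-butyl-bearing ester, combined with a methyl on the carbon, fell well below compound 1. The step of a number 5.4 percentage points higher from compound 2 to compound 3 (within the scatter) lay within the scatter.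

He therefore expects a modest rise in this assay from compound 3 to compound 4, a number 9.5 percentage points higher from compound 3 to compound 4 (within the scatter), short of compound 1. Compound 4 is estimated at 8%, within -8% to 24%.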

Compound 4, a percentage reported as inhibition, at one concentration (the size of the read-out at that concentration, not a potency): 0.7%
For compound 4 the middle estimate is 7.3 percentage points above the measured one, and the stated range covers the measured number.
By their numbers in this assay, from the lowest: compounds 2, 3 and 4 (each within the scatter of the next); then compound 1.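

In this assay the exchange of trichloromethyl for ((tert-butyl)carbonyl)oxy moves the number only within the scatter (a number 2.2 percentage points higher from compound 3 to compound 4 (within the scatter)), and so does hydrogen in place of methyl on the saturated chain carbon bound to two oxygens next to a carbonyl group (a number 7.6 percentage points higher from compound 2 to compound 4 (within the scatter)). Compound 1 stays apart from compound 4 by a single methyl in place of hydrogen on the saturated chain carbon bound to a carbonyl carbon and two saturated chain carbons (a number 15.7 percentage points lower from compound 1 to compound 4 (beyond the scatter)), so the ester's far end, rather than the chain carbon, marks the one gap beyond the scatter among these new steps. Nothing measured here accounts for that gap.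

Going by these compounds, it remains open whether a longer chain or an amine at that far end would match or pass compound 1. These numbers speak only of a stronger or weaker effect at the one concentration tested.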